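Extending the Amine Acyl Group of a Lipopeptide Agonist

The compounds below may be only part of what the source reports. "The series", "measured", "known", "first", "only" and "open" are said of these compounds alone.

Three measured compounds share a lipidated dipeptide core. Compound 1 `CCCCCCCCCCCCCCCC(=O)OCCSC[C@H](N)C(=O)N[C@@H](CO)C(=O)OC` gives 3.63 nM in a functional assay on HEK293 cells for agonist activity at Toll-like receptor 2 (Homo sapiens), read by reporter gene assay, with a stated time of 12 h; a higher number here means that more compound is needed for the effect, a lower number that less compound is needed. Compound 2 `CCCCCCCCCCCCCCCCCC(=O)OCCSC[C@H](N)C(=O)N[C@@H](CO)C(=O)OC`, with a longer lipid chain, gives 4.79 nM. Compound 3 `CCCCCCCCCCCCCCCC(=O)OCCSC[C@H](NC(C)=O)C(=O)N[C@@H](CO)C(=O)OC`, which carries an acetyl on the amine nitrogen, gives 1.01 nM and so stands at the lowest number of the three, clear of both other compounds.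

Compound 4 `CCCCCCCCCCCCCCCC(=O)OCCSC[C@H](NC(=O)CCCCCCC)C(=O)N[C@@H](CO)C(=O)OC` differs from compound 3 by hexyl in place of hydrogen on a saturated chain carbon bound to a carbonyl carbon. Among the measured compounds shown here, no measured step repeats this change exactly, but two bear on it. Lengthening a saturated chain far from the carbonyl gave a 1.3-fold higher number from compound 1 to compound 2 (0.12 log units; within the scatter), a step within the scatter. Placing the acetyl on the amine nitrogen gave a 3.6-fold lower number from compound 1 to compound 3 (0.56 log units; beyond the scatter), a modest step. The chain grown in compound 4 sits on that acetyl, so a small step, if any, is expected, most likely toward a slightly lower number, as a 1.3-fold lower number from compound 3 to compound 4 (0.10 log units; within the scatter). Compound 4 is therefore estimated at 0.8 nM, in a range from 0.2 nM to 4 nM.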

Compound 4, half-maximal effective concentration: 3.8 nM
For compound 4 the middle estimate is 4.8-fold (0.68 log units) below the measured one, within the range that was stated.
By their numbers in this assay, from the lowest: compound 3; then compounds 1, 4 and 2 (each within the scatter of the next).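

In this assay, the position on the amine nitrogen proves sensitive to the length of the acyl group: hexyl in place of hydrogen on the saturated chain carbon bound to the carbonyl carbon gave a 3.8-fold higher number from compound 3 to compound 4 (0.58 log units; beyond the scatter) and so removed the advantage held by the acetyl. Measured against the free amine, heptylcarbonyl in place of hydrogen on the amine nitrogen gave a 1.0-fold higher number from compound 1 to compound 4 (0.02 log units; within the scatter) and so left no detectable difference, which shows that acylating this nitrogen does not by itself lower the number. Nothing available explains why the longer acyl group behaves differently from the acetyl.

Acyl groups of intermediate length, such as butanoyl, remain open, as does a longer one, such as dodecanoyl. On these data alone, it is also open whether an acetyl or heptylcarbonyl group on the amine nitrogen would act the same way with the longer lipid chain of compound 2.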